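Swapping the Aromatic Ring on the Amine Arm

The compounds below may be only part of what the source reports. "The series", "measured", "known", "first", "only" and "open" are said of these compounds alone.

Compound 1 `Brc1cc(NCc2ccco2)c2cn[nH]c2c1`: 64%
Compound 2 `Brc1cc(NCc2cccs2)c2cn[nH]c2c1`: 53%
Compound 3 `Brc1cc(NCc2cnc[nH]2)c2cn[nH]c2c1`: 54%

These three compounds share one core and differ only in the aromatic ring carried on a saturated chain carbon bound to a nitrogen on an aromatic ring. In an assay for inhibition of Tryptophan 2,3-dioxygenase (Homo sapiens), with a stated time of 1 h, tested at 10 uM (a lower number here means less inhibition, a higher number more inhibition at the concentration tested (going by the name of the read-out)), compound 1 gives 64%, compound 2 gives 53% and compound 3 gives 54%. Compound 3 cannot be separated from either of the others: a number 10 percentage points lower from compound 1 to compound 3 (within the scatter) and a number 1 percentage points higher from compound 2 to compound 3 (within the scatter). Within the data shown here, only one step, a number 11 percentage points lower from compound 1 to compound 2 (beyond the scatter), clears the scatter, and it is small.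

Compound 4 `Brc1cc(NCc2ccncc2)c2cn[nH]c2c1` has not yet been measured. It differs from compound 3 in one place: pyridin-4-yl in place of 1H-imidazol-5-yl on a saturated chain carbon bound to a nitrogen on an aromatic ring. All three measured steps exchange the ring in exactly this position, and none shifted the read-out by more than a modest amount. Pyridin-4-yl has no measured partner, so a similar outcome is expected. For compound 4 the estimate is 52%, with a range from 36% to 68%. The expected step of a number 2 percentage points lower from compound 3 to compound 4 (within the scatter) should stay within the scatter.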

Compound 4, a percentage reported as inhibition, at one concentration (the size of the read-out at that concentration, not a potency): 55%
Compound 4: middle estimate off by 3 percentage points, on the low side; measured number inside the range.
By their numbers in this assay, from the lowest: compounds 2, 3, 4 and 1 (each within the scatter of the next, the first and the last beyond it).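

In this assay the change to a six-membered ring, pyridin-4-yl in place of 1H-imidazol-5-yl, gives a number 1 percentage points higher from compound 3 to compound 4 (within the scatter) and opens no clear gap, even though the ring gains a heavy atom and loses its hydrogen-bond donor. The exchanges for the other two five-membered rings give a number 2 percentage points higher from compound 2 to compound 4 (within the scatter) and a number 9 percentage points lower from compound 1 to compound 4 (within the scatter) and so the new ring cannot be separated from any of the three earlier ones, which means that ring size and the donor show no clear effect on the read-out in this set. Nothing available explains why these rings read so alike.

From the compounds shown here alone, all four rings are aromatic, so a saturated ring such as piperidine, or a plain amine or carboxylic acid in the same place, remains untested here. A longer chain between the nitrogen and the ring is also left open.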